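The source may hold more compounds than are shown below. What is called first, only, known or untested is meant among the compounds shown, and "the series" means these compounds.

Three compounds have numbers so far in an ADME assay on microsomes from liver (Rattus norvegicus, strain Sprague-Dawley) for pharmacokinetics, read by LC-MS, using NADPH, with a stated time of 45 min, tested at 1 uM (on this read-out higher numbers stand for fast clearance and lower numbers for slow clearance), as follows:
- compound 1 `COc1cc(OCc2ccnc(N)c2Cl)cc2sc(N[C@@H]3CCCC[C@H]3O)nc12` gives 99 mL/min/kg
- compound 2 `Nc1nccc(COc2cc(Cl)c3nc(N[C@@H]4CCCC[C@H]4O)sc3c2)c1Cl` gives 78 mL/min/kg
- compound 3 `CNC(=O)Nc1nccc(COc2cc(OC)c3nc(N[C@H]4CCCC[C@@H]4O)sc3c2)n1` gives 19 mL/min/kg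

In this assay compound 3 has the lowest of the three numbers, and its gaps to the other two lie beyond the usual scatter. Compounds 1 and 2 differ from compound 3 in more than one place, so no single group can be tied to those gaps.

Compound 4 (`COc1cc(OCc2ccnc(Nc3cn(C)nn3)n2)cc2sc(N[C@H]3CCCC[C@@H]3O)nc12`) has not been measured yet. It carries 1-methyl-1H-1,2,3-triazol-4-yl in place of methylcarbamoyl on a nitrogen on an aromatic ring and otherwise matches compound 3.

Within the data shown here, only one measured step exists, chloro in place of methoxy on an aromatic carbon (a 1.3-fold lower number from compound 1 to compound 2 (0.10 log units; within the scatter)), and it stays within the scatter. That step concerns a different place in the molecule, so it offers little guidance here. Among the measured compounds shown here, no measured step touches this nitrogen, which leaves compound 3 (19 mL/min/kg) as the starting point and calls for wide margins.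

In this assay the expected change is small and slightly upward, no more than the scatter (a 1.3-fold higher number from compound 3 to compound 4 (0.12 log units; within the scatter)). The estimated clearance for compound 4 is (25 mL/min/kg), with the expected range running from 10 mL/min/kg to 60 mL/min/kg at its two ends.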

Compound 4, clearance: 25 mL/min/kg
Compound 4: middle estimate and measured number agree at the digits printed; measured number inside the range.
By their numbers in this assay, from the lowest: compounds 3 and 4 (each within the scatter of the next); then compounds 2 and 1 (each within the scatter of the next).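

In this assay, putting 1-methyl-1H-1,2,3-triazol-4-yl in place of methylcarbamoyl on a nitrogen on an aromatic ring gives a 1.3-fold higher number from compound 3 to compound 4 (0.12 log units; within the scatter), the first step read at this place. The two groups have little in common: methylcarbamoyl has no ring and 1 hydrogen-bond donor, while the group that enters is a five-membered aromatic ring with 3 hetero atoms and 0 hydrogen-bond donors, yet the clearance number stays within the scatter, so for this one pair the swap leaves the read-out unchanged. Nothing available explains why the number holds across so different a swap.

A single pair cannot show how broadly this nitrogen accepts other groups, so an acetyl group, a plain methyl or a six-membered ring such as pyridine could behave quite differently here. Going by these compounds, it also remains open whether chloro in place of methoxy on an aromatic carbon, the step seen between the first two compounds, would stay as small when made on compound 3 or compound 4.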